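Series notes: from compound 1 to compound 4

This account rests on a few compounds, and the source may have more. Where it says the series, first, only, none or still open, it means among the compounds named here.

Compound 1 `N#Cc1ccc(/C=C/S(=O)(=O)Cc2ccc(Nc3ncnc4ccccc34)cc2)cc1` is tested in a functional assay on PC-3 cells (Homo sapiens); a lower number here means a stronger inhibitor of growth, a higher number a weaker inhibitor of growth. For compound 1 the reading > 100000 nM is only a limit of the assay, not a number. Compound 2 `O=S(=O)(/C=C/c1ccc(Cl)c(Cl)c1)Cc1ccc(Nc2ncnc3ccccc23)cc1` gives 35000 nM, and compound 3 `CC(C)(C)c1cc(/C=C/S(=O)(=O)Cc2ccc(Nc3ncnc4ccccc34)cc2)cc(C(C)(C)C)c1O` gives 7000 nM. Within the data shown here, the single measured step touching compound 1 is an at least 2.8-fold lower number from compound 1 to compound 2 (0.45 log units; beyond the scatter); its size rests on the limit of > 100000 nM in this assay, at which 1 of the 3 values shown sits, and so is known only as a floor. Compound 4 `O=S(=O)(/C=C/c1ccc(F)cc1F)Cc1ccc(Nc2ncnc3ccccc23)cc1` carries the change (2,4-difluorophenyl in place of 4-cyanophenyl on a double-bonded chain carbon bound to a double-bonded chain carbon). As in the step to compound 2, 4-cyanophenyl gives way to a halogen-bearing phenyl. For compound 4 a step of similar kind is therefore expected: an at least 2.0-fold lower number from compound 1 to compound 4 (0.30 log units; that floor lies within the scatter). Compound 4 is expected to show 50000 nM, within 15000 nM to 150000 nM.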

Compound 4, concentration for 50% growth inhibition: > 100000 nM
Compound 4 ended at the assay's limit (the forecaster's own chance of this, stated with the estimate: 30%); middle value at least 2.0-fold (0.30 log units) away from the limit.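

Replacing 3,4-dichlorophenyl with 2,4-difluorophenyl on a double-bonded chain carbon bound to a double-bonded chain carbon gives an at least 2.8-fold higher number from compound 2 to compound 4 (0.45 log units; beyond the scatter) in this assay. A halogen-bearing phenyl at this place is therefore not enough on its own to bring the reading down to that of compound 2. The step from compound 1 to compound 4 cannot be read: the limit of > 100000 nM in this assay, at which 2 of the 4 values shown sit.

On these data alone, compound 2 and compound 4 differ in both halogen and ring pattern, and which of the two matters stays open. Also open, as far as these compounds go, is how a phenyl bearing an amine or a carboxylic acid would read here.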